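A few compounds are considered here, and "the series" means these few. Any claim that something is new, unique, unknown or untested is made for them only; others in the source may bear on it.

In a functional assay on HeLa cells (Homo sapiens) for antiproliferative activity, read by MTT assay, with a stated time of 24 h (a lower number here means a stronger inhibitor, a higher number a weaker inhibitor), two compounds have been measured.

Compound 1 `O=[N+]([O-])c1ccc(CSc2nnc(-c3ccc4c(c3)OCCO4)n2-c2ccccc2)cc1` gives 36200 nM
Compound 2 `Fc1ccc(CSc2nnc(-c3ccc4c(c3)OCCO4)n2-c2ccccc2)cc1` gives 46900 nM

Compound 2 cannot be told apart from compound 1, since the two numbers lie within the usual scatter of each other. Compound 3 `Brc1cccc(CSc2nnc(-c3ccc4c(c3)OCCO4)n2-c2ccccc2)c1` keeps the shared core. Its difference from compound 2 is 3-bromophenyl in place of 4-fluorophenyl on a saturated chain carbon bound to a sulfur on a saturated chain carbon bound to a sulfur, where 3-bromophenyl stands in place of 4-fluorophenyl. Within the data shown here, the one measured step that bears on this is a 1.3-fold higher number from compound 1 to compound 2 (0.11 log units; within the scatter) and it also alters that phenyl group, with fluoro in place of nitro. Among the measured compounds shown here, that step stayed within the scatter, but it is a single step, and no bromo compound has been measured. No step beyond the scatter is therefore expected in this assay for this change. The estimated step of a 1.2-fold lower number from compound 2 to compound 3 (0.07 log units; within the scatter) stays within the scatter. For compound 3 the expected value is 40000 nM with an estimated range of 15000 nM to 90000 nM around it.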

Compound 3, half-maximal inhibitory concentration: 44200 nM
Compound 3: the middle estimate sits 1.1-fold (0.04 log units) below what was measured, within the range that was stated.
By their numbers in this assay, from the lowest: compounds 1, 3 and 2 (each within the scatter of the next).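

In this assay, 3-bromophenyl in place of 4-fluorophenyl gives (a 1.1-fold lower number from compound 2 to compound 3 (0.03 log units; within the scatter)), and 3-bromophenyl in place of 4-nitrophenyl gives (a 1.2-fold higher number from compound 1 to compound 3 (0.09 log units; within the scatter)). The earlier pair changed only the group at the 4 place of the phenyl ring, whereas compound 3 changes both the group and its place on the ring, and the number still cannot be told apart from those of compound 1 and compound 2. Nothing available offers a reason for this sameness.

Because bromo and its place change together, the step from compound 2 to compound 3 cannot show what each change does alone, as a 4-bromophenyl group could. From the compounds shown here alone, it also remains open whether an amine or a carboxylic acid on this ring, or a longer chain in place of the benzyl carbon, would move the number beyond the scatter.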